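The source may report more compounds than this note shows. Statements on the series, on what has been measured and on what is new or still open speak of the compounds shown alone.

Working notes on a pyrazole series carrying a nitrile-bearing side chain, profiled in a functional assay on U-251 cells (Homo sapiens) for inhibition, read by sulforhodamine B assay, with a stated time of 48 h; a lower number here means a stronger inhibitor of growth, a higher number a weaker inhibitor of growth. Three compounds have numbers. Compound 1 `COc1cc(C)cc(-c2c(-c3ccnc(-c4ccc(C(C)=O)cc4)c3)cnn2CC#N)c1` gives 2890 nM in this assay. Compound 2 `Cc1cc(O)cc(-c2nn(CC#N)cc2-c2ccnc(-c3ccc(Oc4ccccc4)cc3)c2)c1` gives 1610 nM. Compound 3 `COc1cc(C)cc(-c2nn(CC#N)cc2-c2ccnc(-c3ccc(N(C)C)cc3)c2)c1` gives 415 nM, the lowest of the three; its nearest neighbour on the numbers is compound 2, the furthest is compound 1, and both gaps lie beyond the usual scatter, so compound 3 counts as the strongest growth inhibitor among the measured compounds.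

Compound 4 `Cc1cc(O)cc(-c2nn(CC#N)cc2-c2ccnc(-c3ccc(N(C)C)cc3)c2)c1` is not yet measured. It differs from compound 3 in one place: hydrogen in place of methyl on an oxygen on an aromatic ring. Among the measured compounds shown here, no measured pair shows this change on its own, and the two compounds that already carry the hydroxy or methoxy group (compound 2, compound 1) differ from each other elsewhere as well, so their numbers give no clean step. The expectation is therefore a step from compound 3 to compound 4 of a 1.2-fold higher number from compound 3 to compound 4 (0.06 log units; within the scatter), not beyond the scatter, in either direction. Compound 4 is estimated at 480 nM, with a range from 160 nM to 1500 nM.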

Compound 4, concentration for 50% growth inhibition: 3140 nM
Compound 4: middle estimate off by 6.5-fold (0.82 log units), on the low side; the measured number lies above the stated range.
By their numbers in this assay, from the lowest: compound 3; then compounds 2, 1 and 4 (each within the scatter of the next).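

Among the compounds shown here, this is the first clean reading of the oxygen substituent on the 3-methoxy-5-methylphenyl ring: in this assay, with dimethylamino held constant, methoxy to hydroxy gives a 7.6-fold higher number from compound 3 to compound 4 (0.88 log units; beyond the scatter), so the methyl on this oxygen is not a silent change here, at least in this pair. With hydroxy held constant, dimethylamino in place of phenoxy gives a 2.0-fold higher number from compound 2 to compound 4 (0.29 log units; within the scatter), so this pair is not separated by that swap. Nothing in hand accounts for the methoxy to hydroxy step.

As far as these compounds go, whether that step carries over when phenoxy replaces dimethylamino remains open. Also open, from the compounds shown here alone, is how far the oxygen substituent can be varied, for instance whether an ethoxy group or an amine at this place on the ring behaves like methoxy or like hydroxy.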